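The compounds below may be only part of what the source reports. "The series", "measured", "known", "first", "only" and "open" are said of these compounds alone.

Of the compounds shown here, three sharing one core have been measured in a functional assay on L1210 cells (Mus musculus), with a stated time of 1 days; a lower number here means a less potent compound, a higher number a more potent compound, by a factor of ten per unit of this negative logarithm. Compound 1 `CC1=C(N2CC2)C(=O)C(CCC(=O)N(C)C)=C(N2CC2)C1=O` gives 4.84. Compound 2 `CC1=C(N2CC2)C(=O)C(C(C)C)=C(N2CC2)C1=O` gives 4.69, and a number 0.15 log units lower from compound 1 to compound 2 (within the scatter). Compound 3 `CC1=C(N2CC2)C(=O)C(CCCc2ccccc2)=C(N2CC2)C1=O` gives 3.6, the lowest of the three numbers, standing well apart from compound 2 and compound 1.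

Compound 4 `CC1=C(N2CC2)C(=O)C(CCCOC(N)=O)=C(N2CC2)C1=O` has not yet been measured. It differs from compound 3 in that (carbamoyloxy in place of phenyl on a saturated chain carbon, three bonds along the chain from a double-bonded ring carbon). The measured step that bears on this is a number 1.24 log units lower from compound 1 to compound 3 (beyond the scatter), where a group with a hydrogen-bond acceptor gave way to a carbon-only ring and the number fell sharply. Compound 4 reverses that kind of change, so a rise is expected, a number 1.10 log units higher from compound 3 to compound 4 (beyond the scatter). Compound 4 is therefore estimated at 4.7, within a range from 4.2 to 5.2.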

Compound 4, logarithm of the reciprocal of the active concentration, log(1/C): 5.48
Estimate against measurement, compound 4: 0.78 log units below, and the stated range ends below it.
By their numbers in this assay, from the lowest: compound 3; then compounds 2 and 1 (each within the scatter of the next); then compound 4.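

In this assay, for the compounds shown here, what sits at the end of this side chain matters a great deal: carbamoyloxy in place of phenyl, three bonds along the chain from a double-bonded ring carbon, gives the largest step so far (a number 1.88 log units higher from compound 3 to compound 4 (beyond the scatter)). Compound 4 also stands clear of the isopropyl group (a number 0.79 log units higher from compound 2 to compound 4 (beyond the scatter)) and of the dimethylcarbamoyl chain (a number 0.64 log units higher from compound 1 to compound 4 (beyond the scatter)), though these steps are modest. Nothing measured here explains why this group does best.

Still open, going by these compounds, is whether a hydroxyl or an amine at the chain end would match carbamoyloxy, and whether a longer chain would keep the gain.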